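A Single Fluorine Added to a Benzyl Ether

This account rests on a few compounds, and the source may have more. Where it says the series, first, only, none or still open, it means among the compounds named here.

Compound 3 `Cc1ccc(NC(=O)NC(=O)c2ccc(OCc3ccccc3)cc2)cc1-c1nc2ccccc2[nH]1` gives 16400 nM in a functional assay on HT-29 cells (Homo sapiens) for inhibition, read by MTT assay, with a stated time of 48 h (a lower number here means a stronger inhibitor, a higher number a weaker inhibitor), the second highest of the three numbers measured. Compound 1 `Cc1ccc(NC(=S)NC(=O)c2ccc(OCc3ccc(C(F)(F)F)cc3)cc2)cc1-c1nc2ccccc2[nH]1` gives 17600 nM and compound 2 `Cc1ccc(NC(=S)NC(=O)c2ccc(OCc3cccc(C(F)(F)F)c3)cc2)cc1-c1nc2ccccc2[nH]1` gives 8200 nM; both values lie within the scatter of that of compound 3. Compound 4 `Cc1ccc(NC(=O)NC(=O)c2ccc(OCc3cccc(F)c3)cc2)cc1-c1nc2ccccc2[nH]1` differs from compound 3 by fluoro in place of hydrogen on an aromatic carbon. Going by the values given here, the only measured step, a 2.1-fold lower number from compound 1 to compound 2 (0.33 log units; beyond the scatter), moves a trifluoromethyl group rather than adding a fluoro, so it bears only loosely on this change, and no measured step adds a single fluoro to this ring. The step expected is therefore none beyond the scatter, a 1.2-fold lower number from compound 3 to compound 4 (0.07 log units; within the scatter). Compound 4 is expected to give about 14000 nM, within a range from 5000 nM to 40000 nM.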

Compound 4, half-maximal inhibitory concentration: 38200 nM
For compound 4 the middle estimate is 2.7-fold (0.44 log units) below the measured one, within the range that was stated.
By their numbers in this assay, from the lowest: compounds 2, 3 and 1 (each within the scatter of the next, the first and the last beyond it); then compound 4.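

In this assay, the smallest possible addition to the benzyl ring is not silent: a 2.3-fold higher number from compound 3 to compound 4 (0.37 log units; beyond the scatter) shows that a single fluoro on this aromatic carbon makes the compound a weaker inhibitor. The step is modest, yet it shows that this ring position responds to a change of just one heavy atom. Nothing measured here explains this loss. As far as these compounds go, whether a chloro or a methoxy group at this place would raise the number as well remains open, and so does the effect of fluoro elsewhere on this ring.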